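The source may report more compounds than this note shows. Statements on the series, on what has been measured and on what is new or still open speak of the compounds shown alone.

Working notes on a small set built on one shared core. In a functional assay on CRL2813 cells (Homo sapiens) for cytotoxicity, read by sulforhodamine B assay, with a stated time of 5 days (on this read-out lower numbers stand for stronger inhibition and higher numbers for weaker inhibition), compound 2 `Cc1ccc(NC(=O)N[C@H]2CC[C@H](Oc3ccc(F)cc3)CC2)cc1` returns only a limit, > 20000 nM, so its actual value is not known. In this assay compound 1 `O=C(Nc1cccc(C(F)(F)F)c1)N[C@H]1CC[C@@H](Oc2ccc(F)cc2)CC1` gives 2600 nM, and compound 3 `O=C(Nc1cccc(C(F)(F)F)c1)N[C@H]1CC[C@H](Oc2cccc(C(F)(F)F)c2)CC1` gives 1300 nM. Compound 4 `CSc1cccc(NC(=O)N[C@H]2CC[C@H](Oc3ccc(F)cc3)CC2)c1` has not yet been measured in this assay; it differs from compound 2 by 3-(methylsulfanyl)phenyl in place of 4-methylphenyl on an amide-type nitrogen. Since compound 2 stands at the limit of > 20000 nM in this assay, at which 1 of the 3 values shown sits, any step to compound 4 can only be read against that limit. The step from compound 2 to compound 4 is expected to be an at least 2.5-fold lower number from compound 2 to compound 4 (0.39 log units; beyond the scatter), toward stronger inhibition, with its size uncertain. Compound 4 is estimated at 8000 nM in this assay, within a range from 2500 nM to 25000 nM.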

Compound 4, half-maximal inhibitory concentration: 11100 nM
Compound 4: middle estimate off by 1.4-fold (0.14 log units), on the low side; low and high end bracket the measured number.
By their numbers in this assay, from the lowest: compounds 3 and 1 (each within the scatter of the next); then compound 4. At a limit, above all of these: compound 2.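

This position on the amide-type nitrogen now has a measured number with a group other than trifluoromethyl-substituted phenyl: 3-(methylsulfanyl)phenyl in place of 4-methylphenyl gives an at least 1.8-fold lower number from compound 2 to compound 4 (0.25 log units; that floor lies within the scatter). Compound 2 remains a limit, not a number, in this assay: the limit of > 20000 nM in this assay, at which 1 of the 4 values shown sits.

As far as these compounds go, the size of this step therefore stays open, and the change may be small or large. Also open, from the compounds shown here alone, is whether an amine or a carboxylic acid on the phenyl ring, or a longer chain on its sulfur, would change the number in this assay.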